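Adding a second chloro: from compound 2 to compound 3

The source may report more compounds than this note shows. Statements on the series, on what has been measured and on what is new or still open speak of the compounds shown alone.

Of the compounds shown here, two have been measured so far, and they share one core. In a functional assay, read by spectrophotometry, tested at 100 uM (a lower number here means a stronger inhibitor, a higher number a weaker inhibitor), compound 1 `O=C(/C=C/c1ccc(Cl)cc1)c1cccc(NC(=O)c2cc(-c3ccncc3)n[nH]2)c1` gives 78900 nM, and compound 2 `O=C(/C=C/c1ccccc1Cl)c1cccc(NC(=O)c2cc(-c3ccncc3)n[nH]2)c1` gives 79800 nM. Compound 2 therefore stands level with compound 1, and no order can be drawn between them. Among the measured compounds shown here, the only measured step is a 1.0-fold higher number from compound 1 to compound 2 (0.00 log units; within the scatter), with 2-chlorophenyl in place of 4-chlorophenyl.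

Compound 3 `O=C(/C=C/c1ccc(Cl)cc1Cl)c1cccc(NC(=O)c2cc(-c3ccncc3)n[nH]2)c1` carries 2,4-dichlorophenyl where compound 2 has 2-chlorophenyl: chloro in place of hydrogen on an aromatic carbon. This is chloro in place of hydrogen on an aromatic carbon, so the new ring holds both chloro placements seen singly in compounds 1 and 2. For the measured compounds named here, no measured step adds a chloro, so the evidence is indirect. It rests on a 1.0-fold higher number from compound 1 to compound 2 (0.00 log units; within the scatter), which shows no response in this assay to where the single chloro sits. No step beyond the scatter is therefore expected, in either direction. The expected step is a 1.1-fold lower number from compound 2 to compound 3 (0.06 log units; within the scatter). The estimate for compound 3 is 70000 nM, with an expected range of 35000 nM to 125000 nM.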

Compound 3, half-maximal inhibitory concentration: 80900 nM
Estimate against measurement, compound 3: 1.2-fold (0.06 log units) below; the measured number falls inside the stated range.
By their numbers in this assay, from the lowest: compounds 1, 2 and 3 (each within the scatter of the next).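

In this assay, the first measured addition of a chloro, as distinct from a move of one, gives a 1.0-fold higher number from compound 2 to compound 3 (0.01 log units; within the scatter), so 2,4-dichlorophenyl in place of 2-chlorophenyl produces no readable change at this ring. The same addition read from the other single-chloro compound gives a 1.0-fold higher number from compound 1 to compound 3 (0.01 log units; within the scatter), which means that the 4-chlorophenyl, 2-chlorophenyl and 2,4-dichlorophenyl forms all stand within the scatter of one another, and the ring has so far shown no response to either the placement or the number of chloro groups. No supporting measurement accompanies this result that could explain it.

All three compounds carry only chloro on this ring, so these notes cannot say whether the flat response extends to a different kind of substituent, such as a methoxy group, a hydroxyl group, an amine or a carboxylic acid in the same place, or to the unsubstituted phenyl ring. The shared core is also unchanged throughout, which leaves open whether a change elsewhere in the structure would move the number beyond the scatter.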